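The source may hold more compounds than are shown below. What is called first, only, known or untested is meant among the compounds shown, and "the series" means these compounds.

Compound 2 `CCc1cc(N)c2cc(NC(=O)/C=C/c3ccc(C(F)(F)F)cc3)ccc2n1` carries an ethyl group on its core; in a functional assay on HEK293 cells for activation of melanin-concentrating hormone receptor 1 (Homo sapiens), read by inositol phosphate accumulation (a higher number here means that more compound is needed for the effect, a lower number that less compound is needed), compound 2 gives 110 nM. Going by the values given here, its only comparison is compound 1 `Nc1cc(C2CCCC2)nc2ccc(NC(=O)/C=C/c3ccc(C(F)(F)F)cc3)cc12`, which carries a cyclopentyl group in place of that ethyl; in this assay compound 1 gives 68 nM. The step of a 1.6-fold higher number from compound 1 to compound 2 (0.21 log units; within the scatter) lies within the scatter, so these two numbers cannot be told apart, and compound 2 is not separated from compound 1.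

Compound 3 `CCC(C)c1cc(N)c2cc(NC(=O)/C=C/c3ccc(C(F)(F)F)cc3)ccc2n1` differs from compound 2 by ethyl in place of hydrogen on a saturated chain carbon bound to an aromatic carbon and a saturated chain carbon. Among the compounds with values here, the one measured step bears on this only loosely: exchanging cyclopentyl for ethyl at this place moved the number little, so growing the ethyl into a sec-butyl is expected to move it little as well, perhaps slightly toward a lower number. The step of a 1.4-fold lower number from compound 2 to compound 3 (0.14 log units; within the scatter) is therefore expected to stay within the scatter. Compound 3 is estimated at 80 nM, with a range from 30 nM to 250 nM.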

Compound 3, half-maximal effective concentration: 44 nM
Compound 3: middle estimate off by 1.8-fold (0.26 log units), on the high side, within the range that was stated.
By their numbers in this assay, from the lowest: compounds 3, 1 and 2 (each within the scatter of the next, the first and the last beyond it).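

In this assay, going by these compounds alone, turning ethyl into sec-butyl gives a 2.5-fold lower number from compound 2 to compound 3 (0.40 log units; beyond the scatter) as a modest step, and it is the first step at this place on the core to lie beyond the scatter, so a change here can shift the number measurably. The open-chain sec-butyl and the ring-shaped cyclopentyl cannot be told apart, with a 1.5-fold lower number from compound 1 to compound 3 (0.19 log units; within the scatter) within the scatter, so among these compounds a ring at this place is not required for a number at this level. Nothing available explains why the added ethyl lowers the number.

As far as these compounds go, it remains open whether the number keeps falling with a longer chain, such as hexyl, or with a more branched group, such as tert-butyl. From the compounds shown here alone, it is equally open how this place would respond to a group containing nitrogen or oxygen, such as an amine or a carboxylic acid.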